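The source may report more compounds than this note shows. Statements on the series, on what has been measured and on what is new or still open speak of the compounds shown alone.

Measured compounds in an ADME assay on Vero cells (Chlorocebus sabaeus) for cytotoxicity, read by sulforhodamine B assay, with a stated time of 3 days; on this read-out lower numbers stand for higher toxicity in this test and higher numbers for lower toxicity in this test:
Compound 1 `CC1=C(C(=O)Nc2ccc(Cl)cc2)C(c2ccccc2)C(C(=O)Nc2ccc(Cl)cc2)=C(C)N1` gives 15 ug/mL.
Compound 2 `CC1=C(C(=O)Nc2ccc(Cl)cc2)C(c2ccncc2)C(C(=O)Nc2ccc(Cl)cc2)=C(C)N1` gives 78 ug/mL.
Compound 3 `CC1=C(C(=O)Nc2ccc(Cl)cc2)CC(C(=O)Nc2ccc(Cl)cc2)=C(C)N1` gives 40 ug/mL.

Compound 3 stands second highest of these three numbers. The step of a 2.0-fold lower number from compound 2 to compound 3 (0.29 log units; within the scatter) is within the scatter, whereas the step of a 2.7-fold higher number from compound 1 to compound 3 (0.43 log units; beyond the scatter) lies beyond it, so only compound 1 is clearly set apart from compound 3.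

Compound 4 `CC1=C(C(=O)Nc2ccc(Cl)cc2)C(c2ccc(N(C)C)cc2)C(C(=O)Nc2ccc(Cl)cc2)=C(C)N1` differs from compound 3 by 4-(dimethylamino)phenyl in place of hydrogen on a saturated ring carbon. Going by the values given here, two measured steps bear on this change, both read in reverse: putting phenyl onto that saturated ring carbon, the reverse of a 2.7-fold higher number from compound 1 to compound 3 (0.43 log units; beyond the scatter), gave a modestly lower number, while putting pyridin-4-yl there, the reverse of a 2.0-fold lower number from compound 2 to compound 3 (0.29 log units; within the scatter), gave no change beyond the scatter. Neither step covers a 4-(dimethylamino)phenyl group, so the direction is uncertain; a modest shift toward a lower number in this assay, or none beyond the scatter, is the expectation. Compound 4 is therefore estimated at 25 ug/mL, with a range from 10 ug/mL to 70 ug/mL, which means an expected step of a 1.6-fold lower number from compound 3 to compound 4 (0.20 log units; within the scatter).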

Compound 4, half-maximal cytotoxic concentration: 155 ug/mL
For compound 4 the middle estimate is 6.2-fold (0.79 log units) below the measured one; the measured number lies above the stated range.
By their numbers in this assay, from the lowest: compound 1; then compounds 3, 2 and 4 (each within the scatter of the next, the first and the last beyond it).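

In this assay, the saturated ring carbon proves able to carry an aryl group without a lower number than hydrogen gives (a 3.9-fold higher number from compound 3 to compound 4 (0.59 log units; beyond the scatter)), whereas phenyl at that place had gone the other way. On that phenyl group, dimethylamino in place of hydrogen on an aromatic carbon separates the two compounds widely (a 10-fold higher number from compound 1 to compound 4 (1.01 log units; beyond the scatter)), so one substituent there decides on which side of the hydrogen compound the number falls. Against pyridin-4-yl at the same carbon, the change stays within the scatter (a 2.0-fold higher number from compound 2 to compound 4 (0.30 log units; within the scatter)), so these two aryl groups cannot be told apart here.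

Nothing measured alongside these numbers explains the shifts.

On these data alone, it remains open whether another amine, such as pyrrolidine or morpholine, or a methoxy group on that aromatic carbon would do the same.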